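This account rests on a few compounds, and the source may have more. Where it says the series, first, only, none or still open, it means among the compounds named here.

Working notes on the series in a functional assay on XF498 cells (Homo sapiens) for cytotoxicity, read by MTT assay, with a stated time of 72 h; on this read-out higher numbers stand for weaker inhibition and lower numbers for stronger inhibition. Of the compounds shown here, three with a shared core have been measured: compound 1 (`CCOc1ccc(NC2=CC(=O)c3ncncc3C2=O)cc1`) gives 0.03 ug/mL, compound 2 (`O=C1C(Nc2ccc(F)cc2)=CC(=O)c2ncncc21`) gives 0.04 ug/mL and compound 3 (`O=C1C(Nc2ccc(Br)cc2)=CC(=O)c2ncncc21`) gives 0.03 ug/mL. Compound 2 thus stands within the scatter of both other compounds, and no order can be drawn among the three.

Compound 4 (`O=C1C(Nc2ccc(Cl)cc2)=CC(=O)c2ncncc21`) is not yet measured in this assay. Its structure departs from that of compound 2 in one substituent: chloro in place of fluoro on an aromatic carbon. This is chloro in place of fluoro on an aromatic carbon, on a six-membered aromatic ring of carbon only, para to a large group.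

The nearest measured precedent is another halogen exchange, a 1.3-fold lower number from compound 2 to compound 3 (0.12 log units; within the scatter). Two further steps bear on the same substituent: a 1.3-fold higher number from compound 1 to compound 2 (0.12 log units; within the scatter) and no change at the digits printed from compound 1 to compound 3 (within the scatter). All three stay within the scatter, so these data offer no basis for expecting a real shift, in either direction, from the new exchange. The expected change is a 1.1-fold lower number from compound 2 to compound 4 (0.06 log units; within the scatter), which is not expected to exceed the scatter. For compound 4 the estimated value is 0.035 ug/mL, with an expected range of 0.015 ug/mL to 0.08 ug/mL.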

Compound 4, half-maximal inhibitory concentration: 0.01 ug/mL
Compound 4: middle estimate off by 3.5-fold (0.54 log units), on the high side; measured number outside the range, below it.
By their numbers in this assay, from the lowest: compound 4; then compounds 1, 3 and 2 (each within the scatter of the next).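

In this assay the position para to a large group is no longer flat: ethoxy, fluoro and bromo could not be told apart there, but chloro separates from all three, with a 4.0-fold lower number from compound 2 to compound 4 (0.60 log units; beyond the scatter) and a 3.0-fold lower number from compound 3 to compound 4 (0.48 log units; beyond the scatter) and a 3.0-fold lower number from compound 1 to compound 4 (0.48 log units; beyond the scatter). Compound 4 is therefore the strongest of the four in this assay by a modest margin, and the result also shows that halogen exchange at this position does not follow the sequence fluoro, chloro, bromo, since chloro stands apart while fluoro and bromo remain within the scatter of each other. Nothing in the available data accounts for this separation of chloro from the other three groups.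

It remains open whether chloro is a singular case at this position or one member of a wider set, as the compounds shown give no reading for iodo, methyl, trifluoromethyl, an amine or a carboxylic acid there. Also open, as far as these compounds go, is whether the chloro advantage carries over when the same group sits elsewhere on the six-membered aromatic ring of carbon only.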